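Benzoxaborole amides: methoxy to ethynyl on the anilide ring

The compounds below may be only part of what the source reports. "The series", "measured", "known", "first", "only" and "open" are said of these compounds alone.

Three compounds share one core and differ only on the anilide ring. Compound 1 `C#Cc1ccc(NC(=O)CCc2cccc3c2B(O)OC3)cc1`, compound 2 `COc1ccc(NC(=O)CCc2cccc3c2B(O)OC3)cc1` and compound 3 `COc1ccccc1NC(=O)CCc1cccc2c1B(O)OC2` have been measured in a functional assay on MDA-MB-231 cells (Homo sapiens) for antiproliferative activity, read by MTT assay, with a stated time of 72 h; a higher number here means a weaker inhibitor, a lower number a stronger inhibitor. In this assay compound 2 gives 850 nM, compound 3 gives 930 nM and compound 1 gives 6600 nM. The difference between the cores of compound 2 and compound 3 is not broken down here; the two values lie within the scatter of each other. Among the measured compounds shown here, the one counted step is ethynyl in place of methoxy on an aromatic carbon, and it gave a 7.8-fold higher number from compound 2 to compound 1 (0.89 log units; beyond the scatter).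

Compound 4 `C#Cc1ccccc1NC(=O)CCc1cccc2c1B(O)OC2` has not been measured. It differs from compound 3 by ethynyl in place of methoxy on an aromatic carbon. This is the same kind of change as that from compound 2 to compound 1, but the place differs: para to a large group in the earlier pair, ortho to a large group here. Resting on compound 3 at 930 nM and on the earlier step, the expected step in this assay is a 5.4-fold higher number from compound 3 to compound 4 (0.73 log units; beyond the scatter). For compound 4 the estimate is 5000 nM, with a range from 1500 nM to 16000 nM.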

Compound 4, half-maximal inhibitory concentration: 1300 nM
Beside the measured number, compound 4's estimate is 3.8-fold (0.59 log units) above it, and the stated range ends above it.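

In this assay, ethynyl in place of methoxy at the position ortho to a large group gives a 1.4-fold higher number from compound 3 to compound 4 (0.15 log units; within the scatter), so on this core the swap leaves the number within the scatter. Among the compounds shown here, the size of the change therefore does not carry over from one core to the other: the same change on two cores in this assay, a 7.8-fold higher number (0.89 log units; beyond the scatter) from compound 2 to compound 1 and a 1.4-fold higher number (0.15 log units; within the scatter) from compound 3 to compound 4, 5.6-fold (0.74 log units) apart, beyond the scatter of two such steps This does not show what sets the two steps apart, as there is only one pair for each place, and it gives no rule for any other compound.

Open, from the compounds shown here alone, is whether an amine or a carboxylic acid in place of ethynyl on the anilide ring would also give steps that differ between these two cores. Also open, going by these compounds, is whether a longer chain between the amide and the shared core would keep the step seen with compound 3 and compound 4 or the larger one seen with compound 2 and compound 1.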